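Swapping ethyl for cyclobutyl on an aromatic nitrogen

The source may report more compounds than this note shows. Statements on the series, on what has been measured and on what is new or still open speak of the compounds shown alone.

Compound 1 `CN(C)C(=O)CN1CCC(c2cc3c(-c4ccc(=O)n(C5CCOCC5)c4)ccnc3[nH]2)CC1`: 8.2 uL/min
Compound 2 `CCn1cc(-c2ccnc3[nH]c(C4CCN(CC(=O)N(C)C)CC4)cc23)ccc1=O`: < 3 uL/min

Both compounds were run in an ADME assay on microsomes from liver (Homo sapiens) for metabolic stability; a higher number here means faster removal of the compound, a lower number slower removal. Compound 1 gives 8.2 uL/min. For compound 2 the reading is a limit of the assay rather than a number, < 3 uL/min, as the sign shows (the limit of < 3 uL/min in this assay, at which 1 of the 2 values shown sits). Compound 2 thus sits at the lowest reading of the two, and the step of an at least 2.7-fold lower number from compound 1 to compound 2 (0.43 log units; beyond the scatter) came with ethyl in place of oxan-4-yl on the aromatic nitrogen.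

Compound 3 `CN(C)C(=O)CN1CCC(c2cc3c(-c4ccc(=O)n(C5CCC5)c4)ccnc3[nH]2)CC1` has not yet been measured. It differs from compound 2 by cyclobutyl in place of ethyl on an aromatic nitrogen. Among the measured compounds shown here, the only measured step that bears on this change is an at least 2.7-fold lower number from compound 1 to compound 2 (0.43 log units; beyond the scatter), where a ring left the aromatic nitrogen and the number fell to the limit. Cyclobutyl puts a ring back in that place, though a smaller one of carbon only, so for compound 3 a modest rise in this assay is expected, an at least 1.5-fold higher number from compound 2 to compound 3 (0.17 log units; that floor lies within the scatter). Compound 3 is estimated at 4.5 uL/min, within 2.5 uL/min to 9 uL/min.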

Compound 3, intrinsic clearance in a liver preparation (reported as CLH), per the amount of preparation that the assay uses: < 3 uL/min
Compound 3: only a limit was reported (the forecaster's own chance of this, stated with the estimate: 35%); middle value at least 1.5-fold (0.17 log units) away from the limit.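

Having a ring on the aromatic nitrogen is thus not enough on its own to keep the number up in this assay: cyclobutyl in place of oxan-4-yl gives an at least 2.7-fold lower number from compound 1 to compound 3 (0.43 log units; beyond the scatter). Of the three compounds shown, only compound 1, with oxan-4-yl, gives a reading clear of the limit. Compound 2 and compound 3 both give a limit rather than a number, so the step from ethyl to cyclobutyl cannot be read, and any difference between them is hidden from this assay: the limit of < 3 uL/min in this assay, at which 2 of the 3 values shown sit.

Going by these compounds, what a cyclohexyl group, with carbon in place of the ring oxygen of oxan-4-yl, would give at this position stays open. So does the question of whether ring size or that oxygen goes with the higher number of compound 1.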